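This account rests on a few compounds, and the source may have more. Where it says the series, first, only, none or still open, it means among the compounds named here.

Measured so far:
- compound 1, `COC(C)CO[C@H](CC=C(C)C)C1=CC(=O)c2c(O)ccc(O)c2C1=O`: 53400 nM in a functional assay on HeLa cells (Homo sapiens) for cytotoxicity, read by MTT assay; a higher number here means a weaker inhibitor, a lower number a stronger inhibitor
- compound 2, `CCCCC(CC(=O)O[C@H](CC=C(C)C)C1=CC(=O)c2c(O)ccc(O)c2C1=O)OC(C)=O`: 73500 nM in this assay

Compound 2 carries the higher of the two numbers, but its gap to compound 1 lies within the scatter, so the two measured compounds are not separated by this assay. Among the measured compounds shown here, no step between measured compounds is available for the ester side chain, so nothing here shows how a change at that position moves the read-out.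

Compound 3, `CC[C@@](C)(O)CC(=O)O[C@H](CC=C(C)C)C1=CC(=O)c2c(O)ccc(O)c2C1=O`, is not yet measured in this assay. It differs from compound 2 as follows:
1-hydroxy-1-methylpropyl in place of 1-acetoxypentyl on a saturated chain carbon bound to a carbonyl carbon

For the measured compounds named here, with both measured compounds sitting within the scatter of each other, and no measured step touching the side chain, the expected step is a 1.2-fold lower number from compound 2 to compound 3 (0.09 log units; within the scatter), that is, no change beyond the scatter in either direction. Compound 3 is therefore estimated at 60000 nM in this assay, with a range from 25000 nM to 150000 nM.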

Compound 3, half-maximal inhibitory concentration: 17900 nM
Beside the measured number, compound 3's estimate is 3.4-fold (0.53 log units) above it; the whole stated range lies above it.
By their numbers in this assay, from the lowest: compound 3; then compounds 1 and 2 (each within the scatter of the next).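

In this assay, the side chain position does move the read-out, which the earlier pair could not show: 1-hydroxy-1-methylpropyl in place of 1-acetoxypentyl on a saturated chain carbon bound to a carbonyl carbon gives a 4.1-fold lower number from compound 2 to compound 3 (0.61 log units; beyond the scatter) in this series. Against the ether side chain, (2-hydroxy-2-methylbutyl)carbonyl in place of 2-methoxypropyl on an oxygen on a saturated carbon gives a 3.0-fold lower number from compound 1 to compound 3 (0.47 log units; beyond the scatter), so compound 3 stands apart from both earlier compounds, with each step modest. Nothing available bears on the reason for this shift.

The change from compound 2 to compound 3 swaps the acetoxy group for a hydroxyl and shortens the chain in a single move, so the two remain unseparated. A 1-hydroxypentyl group would keep the chain and change only the acetoxy group, and a 1-methoxy-1-methylpropyl group would test the hydroxyl itself.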